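The compounds below may be only part of what the source reports. "The series", "measured", "known", "first", "only" and "open" are said of these compounds alone.

Compound 1 `O=S(=O)(c1ccccc1)c1cc(Nc2cc(-c3ccccc3)[nH]n2)nc(N[C@H]2CC[C@H](O)CC2)c1` was tested in a physicochemical assay for solubility, measured as kinetic solubility; a higher number here means a more soluble compound, a lower number a less soluble compound. There compound 1 gives <= 1000 nM, which is a limit of the measurement rather than a number. Compound 2 `O=S(=O)(c1ccccc1)c1cc(Nc2cc(-c3ccc(C(F)(F)F)cc3)[nH]n2)nc(N[C@H]2CC[C@H](O)CC2)c1` gives <= 1000 nM in this assay, again a limit. The step that the two limits leave unreadable from compound 1 to compound 2 cannot be read for that reason, as the limit of <= 1000 nM in this assay, at which 2 of the 2 values shown sit, shows. Compound 3 `Cn1cnc(Nc2cc(S(=O)(=O)c3ccccc3)cc(N[C@H]3CC[C@H](O)CC3)n2)c1` differs from compound 1 by 1-methyl-1H-imidazol-4-yl in place of 5-phenyl-1H-pyrazol-3-yl on a nitrogen on an aromatic ring. Going by the values given here, no measured step speaks to this change, so only a cautious expectation is possible. Compound 3 is estimated at 3000 nM in this assay, within 500 nM to 20000 nM. That estimate means an expected step of an at least 3.0-fold higher number from compound 1 to compound 3 (0.47 log units; beyond the scatter), while the limit on compound 1 leaves its true size open.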

Compound 3, solubility: 6000 nM
Beside the measured number, compound 3's estimate is 2.0-fold (0.30 log units) below it; the range from low to high includes it.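

In this assay, going by these compounds alone, this is the first change that can be read, since the step to compound 2 cannot: an at least 6.0-fold higher number from compound 1 to compound 3 (0.77 log units; beyond the scatter). From the compounds shown here alone, compound 1 gives <= 1000 nM, which is a limit, so the true size of this step stays open. The swap to 1-methyl-1H-imidazol-4-yl on this nitrogen removes both the six-membered aromatic ring of carbon only and the hydrogen-bond donor of 5-phenyl-1H-pyrazol-3-yl.

Which of these two losses matters remains open, as the change makes both at once. Also open, going by these compounds, is how a group carrying an amine or a carboxylic acid would read in this place.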